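Amide variation on a weak antiproliferative series

A few compounds are considered here, and "the series" means these few. Any claim that something is new, unique, unknown or untested is made for them only; others in the source may bear on it.

Measured so far:
compound 1, `O=C(Nc1ccc(Cl)c(-c2nnc3c(Cl)cccn23)c1)c1ccccn1`: 92000 nM
compound 2, `O=C(Nc1ccc(Cl)c(-c2nnc3c(Cl)cccn23)c1)c1ccc(Cl)cc1Cl`: > 100000 nM (a limit)
compound 3, `O=C(Nc1ccc(Cl)c(-c2nnc3c(Cl)cccn23)c1)c1ccon1`: > 100000 nM (a limit)

In a functional assay on MDA-MB-231 cells (Homo sapiens) for antiproliferative activity, read by MTT assay, with stated times of 72 h and 4 h (a higher number here means a weaker inhibitor, a lower number a stronger inhibitor), compound 1 gives 92000 nM. For compound 2 the assay reports only a limit, > 100000 nM. For compound 3 the assay likewise reports only a limit, > 100000 nM. Compound 3 therefore stands at the top edge of what this assay can resolve, a position shared by two of the three values (the limit of > 100000 nM in this assay, at which 2 of the 3 values shown sit); nothing separates it from compound 2, and the gap to compound 1 is not readable either.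

Compound 4, `O=C(Nc1ccc(Cl)c(-c2nnc3c(Cl)cccn23)c1)c1cccnc1Cl`, is the next entry in the amide series: 2-chloropyridin-3-yl in place of 1,2-oxazol-3-yl on a carbonyl carbon.

For the measured compounds named here, the steps that bear on this are an at least 1.0-fold higher number from compound 1 to compound 2 (0.03 log units; that floor lies within the scatter) and an at least 1.0-fold higher number from compound 1 to compound 3 (0.03 log units; that floor lies within the scatter); the step that the two limits leave unreadable from compound 2 to compound 3. Every change so far at the carbonyl carbon has left the number at or near the limit, so for the replacement in compound 4 no step beyond the scatter is expected, and the estimated step is a number no higher from compound 3 to compound 4 (the limit leaves the size open). For compound 4 in this assay the expected value is 100000 nM, with a range from 40000 nM to 300000 nM, and a further limit rather than a number is considered likely.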

Compound 4, half-maximal inhibitory concentration: 89700 nM
Compound 4: middle estimate off by 1.1-fold (0.05 log units), on the high side, and the stated range covers the measured number.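

In this assay, compound 4 is the second compound in the amide series to give a number rather than a limit, showing that a measurable value at this carbonyl carbon is not confined to pyridin-2-yl. Comparisons with the two limit compounds give only floors: an at least 1.1-fold lower number from compound 3 to compound 4 (0.04 log units; that floor lies within the scatter) and an at least 1.1-fold lower number from compound 2 to compound 4 (0.04 log units; that floor lies within the scatter). The comparison between the two numbers gives a 1.0-fold lower number from compound 1 to compound 4 (0.01 log units; within the scatter), so 2-chloropyridin-3-yl and pyridin-2-yl cannot be told apart in this assay, and the added chlorine and the different ring attachment bring no readable change in the number.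

On these data alone, it remains open whether any group on this carbonyl carbon can move the number beyond the scatter, as the series still lies at the edge of what the assay resolves: the limit of > 100000 nM in this assay, at which 2 of the 4 values shown sit. What an aliphatic amine, a carboxylic acid or a longer alkyl chain would give on this carbonyl carbon also remains open, as does the effect of any change to the shared core.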